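Pyrimidinyl for Phenyl on the Piperazine Nitrogen

This account rests on a few compounds, and the source may have more. Where it says the series, first, only, none or still open, it means among the compounds named here.

Compound 1 `N#Cc1ccc(Nc2nc(Oc3ccnc4ccccc34)nc(N3CCCCC3)n2)cc1C(F)(F)F` gives > 100000 nM in a functional assay on DU-145 cells (Homo sapiens) for cytotoxicity, read by sulforhodamine B assay, with a stated time of 48 h (on this read-out higher numbers stand for lower toxicity in this test and lower numbers for higher toxicity in this test), which is a limit. Compound 2 `CC(C)N1CCN(c2nc(Nc3ccc(C#N)c(C(F)(F)F)c3)nc(Oc3ccnc4ccccc34)n2)CC1` gives > 100000 nM in this assay, again a limit. Compound 3 `N#Cc1ccc(Nc2nc(Oc3ccnc4ccccc34)nc(N3CCN(c4ccccc4)CC3)n2)cc1C(F)(F)F` gives > 100000 nM in this assay, also a limit.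

Compound 3 therefore stands where every measured value sits, at the limit of > 100000 nM in this assay, at which 3 of the 3 values shown sit. Compound 4 `N#Cc1ccc(Nc2nc(Oc3ccnc4ccccc34)nc(N3CCN(c4ncccn4)CC3)n2)cc1C(F)(F)F` differs from it by pyrimidin-2-yl in place of phenyl on an amine nitrogen in a ring. Of the measured steps, a step that the two limits leave unreadable from compound 1 to compound 2, a step that the two limits leave unreadable from compound 1 to compound 3 and a step that the two limits leave unreadable from compound 2 to compound 3 bear on this series, but none of them is readable, since each joins two limits. For the measured compounds named here, no step of known size exists to carry over, so for compound 4 in this assay the expectation is a further limit rather than a readable number, with a number no higher from compound 3 to compound 4 (the limit leaves the size open) expected to be nil. Compound 4 is thus estimated at 100000 nM, within 30000 nM to 300000 nM.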

Compound 4, concentration lethal to 50% of the cells: > 100000 nM
Compound 4 was reported as a limit (the forecaster's own chance of this, stated with the estimate: 85%); the middle value sits exactly at the limit.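

Compound 4 gives a limit, as do compound 1, compound 2 and compound 3, so none of the steps to compound 4 can be read: the limit of > 100000 nM in this assay, at which 4 of the 4 values shown sit. The compounds shown leave open whether pyrimidin-2-yl, phenyl and isopropyl differ at all in this assay.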